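Trimming an Amine: Plasma Stability of Compound 4

The compounds below may be only part of what the source reports. "The series", "measured", "known", "first", "only" and "open" are said of these compounds alone.

Of the compounds shown here, three have been measured in an ADME assay on a cell-free system (plasma, Homo sapiens) for metabolic stability; a higher number here means that the compound lasts longer, a lower number that the compound disappears faster. Compound 1, `CCOC(=O)c1ccc(/N=N/N(C)C(=O)OCOC(=O)c2ccccc2OC(C)=O)cc1`, gives 0.0167 h in this assay, the shortest survival of the three. Compound 2, `Cc1cn(CCOC(=O)CC[C@H](N)C(=O)N(C)CC(=O)O)c(=O)[nH]c1=O`, gives 1.02 h, the longest. Compound 3, `CCN(CC)Cc1cccc(C(=O)OCCOCn2cnc3c(=O)[nH]c(N)nc32)c1`, gives 0.125 h, which places it second of the three: its number lies above that of compound 1 and below that of compound 2, and both gaps are beyond the usual scatter of repeated measurements.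

Compound 4, `CN(C)Cc1cccc(C(=O)OCCOCn2cnc3c(=O)[nH]c(N)nc32)c1`, has not yet been measured. It differs from compound 3 in one place only: dimethylamino in place of diethylamino on a saturated chain carbon bound to an aromatic carbon. The shared core and the linking chain are otherwise unchanged.

Within the data shown here, no pair of measured compounds shares this kind of change, so there is no earlier step to lean on. The change is small in count and leaves the shared core untouched, so the half-life of compound 4 is expected to stay close to that of compound 3, with no step beyond the scatter in either direction. The expected step is a 1.0-fold lower number from compound 3 to compound 4 (0.02 log units; within the scatter). Compound 4 is therefore estimated at 0.12 h, within a range from 0.05 h to 0.3 h.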

Compound 4, half-life: 0.117 h
For compound 4 the middle estimate is 1.0-fold (0.01 log units) above the measured one, within the range that was stated.
By their numbers in this assay, from the lowest: compound 1; then compounds 4 and 3 (each within the scatter of the next); then compound 2.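

In this assay, among these compounds, placing dimethylamino where diethylamino stood, on a saturated chain carbon bound to an aromatic carbon, gives a 1.1-fold lower number from compound 3 to compound 4 (0.03 log units; within the scatter) and is the first step measured between two compounds that differ in one place. The group goes from 5 heavy atoms to 3, yet the two half-lives cannot be told apart, so at this place and in this setting, the difference between these two amines leaves no readable mark on survival in this assay. No measurement shown here gives a reason for this result, so it stands as an observation without an explanation.

The compounds shown leave open how a more different group would behave at this place, such as a morpholine ring, a primary amine or a carboxylic acid in place of dimethylamino. Among the compounds shown here, they also leave open whether swapping diethylamino for dimethylamino would give a similar result on another core, as this single pair is the only evidence for this change and cannot establish a general rule.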